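A few compounds are considered here, and "the series" means these few. Any claim that something is new, unique, unknown or untested is made for them only; others in the source may bear on it.

Compound 3 `O=C(CN1CN(c2ccccc2)C2(CCN(C(=O)c3ccc(C4CCCCC4)cc3)CC2)C1=O)N1CCCCC1` stands second highest of the three numbers in an assay on HEK293 cells for displacement of a labelled ligand from NPC1-like intracellular cholesterol transporter 1 (Homo sapiens) (on this read-out higher numbers stand for weaker inhibition and lower numbers for stronger inhibition), where compound 3 gives 1100 nM. Compound 1 `CC(C)(C)c1ccc(C(=O)N2CCC3(CC2)C(=O)N(CC(=O)NCCO)CN3c2ccccc2)cc1` gives 1000 nM, a value within the scatter of compound 3, while compound 2 `COC(=O)CCCNC(=O)CN1CN(c2ccccc2)C2(CCN(C(=O)c3ccc(C4CCCCC4)cc3)CC2)C1=O` gives 2500 nM. Within the data shown here, the only measured step at the carbonyl carbon is a 2.3-fold lower number from compound 2 to compound 3 (0.36 log units; beyond the scatter), a modest one. Compound 4 `O=C(CN1CN(c2ccccc2)C2(CCN(C(=O)c3ccc(C4CCCCC4)cc3)CC2)C1=O)NCCO` differs from compound 3 by (2-hydroxyethyl)amino in place of piperidin-1-yl on a carbonyl carbon. Compound 1 already carries the same (2-hydroxyethyl)amino group on a different core and gives 1000 nM, within the scatter of compound 3, so the data offer only an indirect hint. The step is therefore expected to be a 1.1-fold higher number from compound 3 to compound 4 (0.04 log units; within the scatter), nothing beyond the scatter. Compound 4 is estimated at 1200 nM, with a range from 500 nM to 3000 nM.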

Compound 4, half-maximal inhibitory concentration: 2000 nM
For compound 4 the middle estimate is 1.7-fold (0.22 log units) below the measured one; measured number inside the range.
By their numbers in this assay, from the lowest: compounds 1, 3, 4 and 2 (each within the scatter of the next, the first and the last beyond it).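

In this assay, (2-hydroxyethyl)amino in place of piperidin-1-yl on this carbonyl carbon gives a step within the scatter (a 1.8-fold higher number from compound 3 to compound 4 (0.26 log units; within the scatter)), so here the ring can be replaced by the open chain without a clear loss. Hydroxy in place of (methoxycarbonyl)methyl on the saturated chain carbon (a 1.3-fold lower number from compound 2 to compound 4 (0.10 log units; within the scatter)) and cyclohexyl in place of tert-butyl on the aromatic carbon (a 2.0-fold higher number from compound 1 to compound 4 (0.30 log units; within the scatter)) likewise stay within the scatter. Nothing available explains these results. As far as these compounds go, whether a carboxylic acid or an amine at the end of the chain would shift the number beyond the scatter remains open. So does the effect of a longer chain carrying the hydroxy group.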